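Shortening the aryl ether chain to a carboxymethyl group

This account rests on a few compounds, and the source may have more. Where it says the series, first, only, none or still open, it means among the compounds named here.

Compound 1 `CCC(CC)(c1ccc(OCCCO)c(C)c1)c1ccc(OCC(O)C(C)(C)C)c(OCC(O)C(C)(C)C)c1` and compound 2 `CCC(CC)(c1ccc(OCCCCCCCO)c(C)c1)c1ccc(OCC(O)C(C)(C)C)c(OCC(O)C(C)(C)C)c1` share a core and differ only in the chain on one aryl ether oxygen. In an assay on cells for binding affinity to vitamin D3 receptor (Homo sapiens), read by fluorescence, tested at 1 uM (a higher number here means more inhibition at the concentration tested (going by the name of the read-out), a lower number less inhibition), compound 1 gives 76%, whereas compound 2 gives 5%. Among the compounds with values here, the single measured step, a number 71 percentage points lower from compound 1 to compound 2 (beyond the scatter), lengthens that chain and removes most of the read-out. Within the data shown here, on these two numbers compound 2 stands lowest, with compound 1 the only neighbour and well beyond the scatter above it.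

Compound 3 `CCC(CC)(c1ccc(OCC(=O)O)c(C)c1)c1ccc(OCC(O)C(C)(C)C)c(OCC(O)C(C)(C)C)c1` reverses the direction of that step: carboxy in place of 6-hydroxyhexyl on a saturated chain carbon bound to an oxygen on an aromatic ring. Among the measured compounds shown here, the chain becomes shorter than in either measured compound, and the terminal alcohol is exchanged for an acid, for which no step exists. For the measured compounds named here, only the step from compound 1 to compound 2 bears on the question, and it argues that the shorter chain should raise this assay's read-out again, though the acid end is uncharted, so the expectation is broad. The step to compound 3 is estimated at a number 45 percentage points higher from compound 2 to compound 3 (beyond the scatter), upward. Compound 3 is expected to give about 50%, between 15% and 85%.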

Compound 3, a percentage reported as inhibition, at one concentration (the size of the read-out at that concentration, not a potency): 10%
Compound 3: middle estimate off by 40 percentage points, on the high side; measured number below the stated range.
By their numbers in this assay, from the lowest: compounds 2 and 3 (each within the scatter of the next); then compound 1.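

In this assay, the exchange of 2-hydroxyethyl for carboxy on a saturated chain carbon bound to an oxygen on an aromatic ring gives a number 66 percentage points lower from compound 1 to compound 3 (beyond the scatter), so a short chain at this position does not by itself keep the read-out. The exchange of 6-hydroxyhexyl for carboxy gives a number 5 percentage points higher from compound 2 to compound 3 (within the scatter), which places the carboxymethyl compound and the long-chain alcohol level with each other and leaves compound 1 as the only compound shown with a high read-out; the series therefore does not follow a simple rule in which a shorter chain means more inhibition, and compound 3 is the compound that goes against such a rule. No independent measurement is available to explain this result.

The compounds shown leave open whether the loss in compound 3 follows the shorter chain, the acid end or both, as the two change together in a single step. A methyl ether or a primary amine at the end of a chain as long as that of compound 1, and an alcohol on a chain as short as that of compound 3, would begin to separate these two changes.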